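The source may hold more compounds than are shown below. What is called first, only, known or untested is meant among the compounds shown, and "the series" means these compounds.

Compound 1 `CC1OC(OC2CCCCC2OCCCCCC(C(=O)O)C(=O)O)C(O)C(O)C1O`: in a functional assay on HL-60 cells (Homo sapiens) for inhibition (a higher number here means a weaker inhibitor, a lower number a stronger inhibitor), compound 1 gives > 5000000 nM, which is a limit of the assay and not a number.
Compound 2 `CC1OC(OC2CCCCC2OCCCCCCCC(C(=O)O)C(=O)O)C(O)C(O)C1O`: in this assay compound 2 gives > 5000000 nM, again a limit.
Compound 3 `CC1OC(OC2CCCCC2OCCCCCCCCC(C(=O)O)C(=O)O)C(O)C(O)C1O`: in this assay compound 3 gives > 5000000 nM, also a limit.

The three compounds share one core and differ only in the chain that carries the two carboxylic acids. Compound 2 differs from compound 1 by 3,3-dicarboxypropyl in place of dicarboxymethyl on a saturated chain carbon, five bonds along the chain from an oxygen on a saturated carbon. Compound 3 differs from compound 1 by 4,4-dicarboxybutyl in place of dicarboxymethyl on a saturated chain carbon, five bonds along the chain from an oxygen on a saturated carbon. The step that the two limits leave unreadable from compound 1 to compound 2 cannot be sized because all three values sit at the limit of > 5000000 nM in this assay, at which 3 of the 3 values shown sit. The same holds for a step that the two limits leave unreadable from compound 1 to compound 3 and for a step that the two limits leave unreadable from compound 2 to compound 3.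

Compound 4 `CC1OC(OC2CCCCC2OCCCCCCCCCCC(C(=O)O)C(=O)O)C(O)C(O)C1O` has not yet been measured. It differs from compound 3 by 3,3-dicarboxypropyl in place of dicarboxymethyl on a saturated chain carbon, eight bonds along the chain from an oxygen on a saturated carbon. This is the same kind of change as that from compound 1 to compound 2, but not the same: there the new group sits five bonds along the chain from an oxygen on a saturated carbon, here eight bonds along the chain from an oxygen on a saturated carbon.

In this assay the step is expected to be a step that the limit leaves unreadable from compound 3 to compound 4, which means an unreadable step like the earlier one. Compound 4 is estimated to give 10000000 nM, with a range from 3000000 nM to 50000000 nM. This expectation rests on every measured value sitting at the limit of > 5000000 nM in this assay, at which 3 of the 3 values shown sit, so compound 4 is most likely reported as a limit too.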

Compound 4, half-maximal inhibitory concentration: > 5000000 nM
Compound 4 was reported as a limit; the forecaster's own chance of this, stated with the estimate: 90%; the middle value does not contradict the limit.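

In this assay compound 4 gives > 5000000 nM, which is a limit of the assay and not a number. The steps from compound 2 and compound 3 to compound 4 cannot be read, because every value sits at the same limit: the limit of > 5000000 nM in this assay, at which 4 of the 4 values shown sit.

The compounds shown leave open how strongly, if at all, each of compounds 1 to 4 inhibits, and whether chain length changes this.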